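Nitro in Place of Chloro on the Ring of Compound 1

The compounds below may be only part of what the source reports. "The series", "measured", "known", "first", "only" and "open" are said of these compounds alone.

Compound 1 `Cn1c(=O)[nH]c2c(cnn2-c2ccc(Cl)cc2)c1=N` carries a single chloro group on its phenyl ring. In an assay on membranes from brain for binding affinity to adenosine receptor A1 (Rattus norvegicus), read by radioligand binding, tested at 20 uM (on this read-out higher numbers stand for more inhibition at the one concentration tested (going by the name of the read-out) and lower numbers for less inhibition), compound 1 gives 37%, the highest of the three numbers measured. Compound 3 `Cn1c(=O)[nH]c2c(cnn2-c2ccc(Cl)cc2Cl)c1=N` gives 9%, and compound 2 `Cn1c(=O)[nH]c2c(cnn2-c2ccccc2N)c1=N` gives 0%. Going by the values given here, the only measured single step, a number 28 percentage points lower from compound 1 to compound 3 (beyond the scatter), shows that adding a second chloro cut the signal well beyond the scatter. Compound 4 `Cn1c(=O)[nH]c2c(cnn2-c2ccc([N+](=O)[O-])cc2)c1=N` differs from compound 1 by nitro in place of chloro on an aromatic carbon. Among the compounds with values here, no measured step swaps one group for another on this ring, so this change is untested; the data only show that every alteration of the ring so far lowered the signal. A modest drop is therefore expected, a number 12 percentage points lower from compound 1 to compound 4 (beyond the scatter). For compound 4 the estimate is 25%, within 5% to 50%.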

Compound 4, a percentage reported as inhibition, at one concentration (the size of the read-out at that concentration, not a potency): 5%
Beside the measured number, compound 4's estimate is 20 percentage points above it; low and high end bracket the measured number.
By their numbers in this assay, from the lowest: compounds 2, 4 and 3 (each within the scatter of the next); then compound 1.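

In this assay, going by these compounds alone, nitro in place of chloro gives a number 32 percentage points lower from compound 1 to compound 4 (beyond the scatter), the first measured exchange of one group for another at this place on the ring. The signal therefore depends on which group sits there, and not only on whether a second group is added, as in compound 3. No measurement here explains why this exchange lowers the signal. As far as these compounds go, whether any group at this place can match or exceed chloro stays open. Methoxy, fluoro or a carboxylic acid there would help to answer that.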